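Thiophene in Place of Furan: Expectation for Compound 4

The compounds below may be only part of what the source reports. "The series", "measured", "known", "first", "only" and "open" are said of these compounds alone.

Compound 1 `Nc1nc(N)c2c(-c3ccoc3)cn([C@@H]3O[C@H](CO)[C@@H](O)[C@H]3O)c2n1`: > 20000 nM
Compound 2 `COc1ncnc2c1c(-c1ccsc1)cn2[C@@H]1O[C@H](CO)[C@@H](O)[C@H]1O`: 3350 nM
Compound 3 `COc1nc(N)nc2c1c(-c1ccoc1)cn2[C@@H]1O[C@H](CO)[C@@H](O)[C@H]1O`: > 20000 nM

Of the compounds shown here, three have been measured in a functional assay on HeLa S3 cells (Homo sapiens) for antiproliferative activity, read by XTT assay, with a stated time of 72 h; on this read-out lower numbers stand for stronger inhibition and higher numbers for weaker inhibition. Compound 1 gives only an assay limit, > 20000 nM. Compound 3 likewise gives only a limit, > 20000 nM. Compound 2 gives 3350 nM. The step that the two limits leave unreadable from compound 1 to compound 3 is consistent with the limit of > 20000 nM in this assay, at which 2 of the 3 values shown sit. Compound 3 therefore stands at the limit, with one further value of the set beside it there.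

Compound 4 `COc1nc(N)nc2c1c(-c1ccsc1)cn2[C@@H]1O[C@H](CO)[C@@H](O)[C@H]1O` differs from compound 3 by thiophen-3-yl in place of furan-3-yl on an aromatic carbon. For the measured compounds named here, no measured step isolates this change; compound 2 carries the same thiophen-3-yl and gives the only numerical value shown. Compound 4 is expected to reach 8000 nM, with a range from 2500 nM to 20000 nM. The expected step is an at least 2.5-fold lower number from compound 3 to compound 4 (0.39 log units; beyond the scatter), and a limit may again be reported.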

Compound 4, half-maximal inhibitory concentration: > 20000 nM
Compound 4: only a limit was reported; the forecaster's own chance of this, stated with the estimate: 40%; middle value at least 2.5-fold (0.39 log units) away from the limit.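

In this assay thiophen-3-yl in place of furan-3-yl leaves compound 4 at a limit, as compound 3 is, so the steps between limits cannot be read. For the compounds shown here, the only readable step is an at least 5.9-fold higher number from compound 2 to compound 4 (0.77 log units; beyond the scatter), which comes with amino in place of hydrogen on an aromatic carbon while thiophen-3-yl stays in place. Compound 4 thus joins the cluster at the assay limit: the limit of > 20000 nM in this assay, at which 3 of the 4 values shown sit.

Going by these compounds, it remains open how furan-3-yl would compare with thiophen-3-yl on the core of compound 2. On these data alone, it also remains open whether a methyl group or a fluorine atom in place of the amino group of compound 4 would give a readable value.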